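Cytotoxicity of a trifluoromethyl benzimidazole series: from phenol to propanamide

The source may hold more compounds than are shown below. What is called first, only, known or untested is meant among the compounds shown, and "the series" means these compounds.

Measured compounds:
compound 1 `O=C(CN1CCCC1)Nc1ccc(-c2nc3cc(C(F)(F)F)ccc3[nH]2)cc1` gives 18000 nM
compound 2 `O=C(CCl)Nc1ccc(-c2nc3cc(C(F)(F)F)ccc3[nH]2)cc1` gives 5000 nM
compound 3 `Oc1ccc(-c2nc3cc(C(F)(F)F)ccc3[nH]2)cc1` gives 17000 nM

These three compounds share one core and differ only in the group on the outer benzene ring. In an ADME assay on MT4 cells (Homo sapiens) for cytotoxicity, read by MTT assay, with a stated time of 96 h (a lower number here means that less compound is tolerated, a higher number that more compound is tolerated), compound 3 stands second highest of the three numbers, and its nearest neighbour is compound 1 a 1.1-fold lower number from compound 1 to compound 3 (0.02 log units; within the scatter), so the two cannot be told apart. Its furthest neighbour is compound 2 a 3.4-fold higher number from compound 2 to compound 3 (0.53 log units; beyond the scatter), a modest step.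

Compound 4 `CCC(=O)Nc1ccc(-c2nc3cc(C(F)(F)F)ccc3[nH]2)cc1` has not yet been measured. propanoylamino in place of hydroxy on an aromatic carbon

Among the compounds with values here, two measured steps bear on this change. The step of a 3.4-fold higher number from compound 2 to compound 3 (0.53 log units; beyond the scatter) shows that removing the amide bearing a chloro gives a higher number, while a 1.1-fold lower number from compound 1 to compound 3 (0.02 log units; within the scatter) shows that the amide bearing a pyrrolidin-1-yl and the hydroxy are within the scatter of each other. Compound 4 carries an amide with neither chloro nor pyrrolidin-1-yl, and the only comparator without chloro, compound 1, sits level with compound 3. Compound 4 is therefore expected to sit close to compound 3, with a step of a 1.1-fold lower number from compound 3 to compound 4 (0.03 log units; within the scatter) that is not expected to exceed the scatter. The estimate for compound 4 in this assay is 16000 nM, within a range from 7000 nM to 35000 nM.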

Compound 4, half-maximal cytotoxic concentration: >= 100000 nM
Compound 4 gave a limit, no number; the forecaster's own chance of this, stated with the estimate: 10%; middle value at least 6.2-fold (0.79 log units) from the limit.
By their numbers in this assay, from the lowest: compound 2; then compounds 3 and 1 (each within the scatter of the next). At a limit, above all of these: compound 4.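

In this assay compound 4 gives >= 100000 nM, which is a limit of the assay and not a number: the limit of >= 100000 nM in this assay, at which 1 of the 4 values shown sits. The earlier compounds shown here left it possible that an amide and a hydroxy on this aromatic carbon would give the same number, but the propanoylamino group shows that the change can matter: an at least 5.8-fold higher number from compound 3 to compound 4 (0.76 log units; beyond the scatter). The group on the saturated chain carbon bound to the carbonyl carbon also counts, with methyl in place of chloro giving an at least 20-fold higher number from compound 2 to compound 4 (1.30 log units; beyond the scatter) and methyl in place of pyrrolidin-1-yl giving an at least 5.5-fold higher number from compound 1 to compound 4 (0.74 log units; beyond the scatter).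

On these data alone, it remains open whether a shorter acetyl amide or a longer chain such as butanoylamino would keep the number as high as in compound 4. As far as these compounds go, it is also open whether a plain amine or a carboxylic acid on the same aromatic carbon would behave like the hydroxy or like the propanoylamino group.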